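This account rests on a few compounds, and the source may have more. Where it says the series, first, only, none or still open, it means among the compounds named here.

Series notes. In an assay on isolated protein for inhibition of histone deacetylase 11 (Homo sapiens), read by mobility shift assay (on this read-out higher numbers stand for weaker inhibition and lower numbers for stronger inhibition), compound 1 `O=C(NO)c1ccc(CN(Cc2ccc(F)cc2)S(=O)(=O)c2c(F)c(F)c(F)c(F)c2F)cc1` gives 787 nM. Among the compounds with values here, compound 2 `Cc1ccc(CN(Cc2ccc(C(=O)NO)cc2)S(=O)(=O)c2c(F)c(F)c(F)c(F)c2F)cc1` gives 73 nM in this assay, the lowest of the two numbers in hand, and the single measured step, an 11-fold lower number from compound 1 to compound 2 (1.03 log units; beyond the scatter), runs toward stronger inhibition. Compound 3 `O=C(NO)c1ccc(CN(Cc2ccncc2)S(=O)(=O)c2c(F)c(F)c(F)c(F)c2F)cc1` is the next entry. The change from compound 2 is pyridin-4-yl in place of 4-methylphenyl on a saturated chain carbon bound to a sulfonamide nitrogen. Within the data shown here, no measured step covers this exchange directly. Among the measured compounds shown here, the only step available, an 11-fold lower number from compound 1 to compound 2 (1.03 log units; beyond the scatter), shows that a single exchange of the group at the outer end of this benzyl arm moves the number a great deal. Compound 3 gives up the methyl of compound 2 and takes in a ring nitrogen, so the cautious expectation is a step back toward the number of compound 1. The expected step is a 5.5-fold higher number from compound 2 to compound 3 (0.74 log units; beyond the scatter). Compound 3 is estimated at 400 nM in this assay, with a range from 120 nM to 1300 nM.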

Compound 3, half-maximal inhibitory concentration: > 1000 nM
Compound 3: no number, only a limit; the forecaster's own chance of this, stated with the estimate: 3%; middle value at least 2.5-fold (0.39 log units) from the limit.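

In this assay compound 3 is held only as a limit, not a number: the limit of > 1000 nM in this assay, at which 1 of the 3 values shown sits. Pyridin-4-yl in place of 4-methylphenyl on a saturated chain carbon bound to a sulfonamide nitrogen gives an at least 13-fold higher number from compound 2 to compound 3 (1.13 log units; beyond the scatter), so this place is sensitive to more than the one exchange seen before, and compound 2 remains the strongest of the three. Against the 4-fluorophenyl arm, the reading is an at least 1.2-fold higher number from compound 1 to compound 3 (0.10 log units; that floor lies within the scatter), which does not set compound 3 apart from compound 1.

From the compounds shown here alone, the true number for compound 3, and with it the full size of both steps, stays open. Also open is how a plain phenyl, a methoxy group on the phenyl ring or an amine on a longer chain would read in the same place, so the three arms shown define no trend.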